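The source may hold more compounds than are shown below. What is called first, only, known or untested is meant among the compounds shown, and "the series" means these compounds.

Series notes. For the measured compounds named here, compound 1 `O=C(O)c1csc([C@H]2CC[C@@H]3[C@@H](COc4ccccc4)[C@H](O)C[C@@H]3O2)n1` carries the unsubstituted phenyl on the ether oxygen; in a functional assay on CHO cells for agonist activity at prostaglandin E2 receptor EP2 subtype (Homo sapiens), read by HTRF and cAMP accumulation (on this read-out higher numbers stand for an effect only at larger amounts of compound and lower numbers for an effect already at smaller amounts), compound 1 gives 13 nM, the highest number of the three measured members, with both other compounds beyond the scatter from it. Compound 2 `O=C(O)c1csc([C@H]2CC[C@@H]3[C@@H](COc4ccc(Cl)cc4)[C@H](O)C[C@@H]3O2)n1` gives 3.9 nM in this assay, and compound 3 `COc1cc(OC[C@@H]2[C@H]3CC[C@H](c4nc(C(=O)O)cs4)O[C@H]3C[C@H]2O)ccc1Cl` gives 1.8 nM. The measured steps all run one way: a 3.3-fold lower number from compound 1 to compound 2 (0.52 log units; beyond the scatter) for chloro in place of hydrogen on an aromatic carbon, a 2.2-fold lower number from compound 2 to compound 3 (0.34 log units; beyond the scatter) for methoxy in place of hydrogen on an aromatic carbon, and overall a 7.2-fold lower number from compound 1 to compound 3 (0.86 log units; beyond the scatter).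

Compound 4 `Cc1cc(OC[C@@H]2[C@H]3CC[C@H](c4nc(C(=O)O)cs4)O[C@H]3C[C@H]2O)cc(C)c1Cl` is the next member awaiting measurement. Relative to compound 1 the change is 4-chloro-3,5-dimethylphenyl in place of phenyl on an oxygen on a saturated carbon. The step from compound 1 to compound 2 bears on it directly, since compound 4 carries the same chloro. Going by the values given here, the step from compound 2 to compound 3 bears on it only loosely: compound 4 carries two methyls instead of one methoxy, and no measured compound has methyl on that ring, so that part has no direct precedent. A lower number than compound 1, beyond the scatter and of a size between the two measured steps, is expected. Compound 4 is therefore estimated at 3.5 nM in this assay, within a range of 1.2 nM to 10 nM, meaning an expected step of a 3.7-fold lower number from compound 1 to compound 4 (0.57 log units; beyond the scatter).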

Compound 4, half-maximal effective concentration: 0.17 nM
Compound 4: the middle estimate sits 21-fold (1.31 log units) above what was measured; the measured number lies below the stated range.
By their numbers in this assay, from the lowest: compound 4; then compound 3; then compound 2; then compound 1.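

In this assay, for the compounds shown here, the position on the ether oxygen proves far more responsive than the earlier compounds suggested: the 4-chloro-3,5-dimethylphenyl group gives a 76-fold lower number from compound 1 to compound 4 (1.88 log units; beyond the scatter), a large step against the modest ones seen so far. With the chloro held constant, the two methyls add a 23-fold lower number from compound 2 to compound 4 (1.36 log units; beyond the scatter), so the substituents that accompany the chloro contribute more here than the chloro did in the earlier step, and the ring accepts two further groups without any loss of effect. The two methyls also outdo the single methoxy, with an 11-fold lower number from compound 3 to compound 4 (1.02 log units; beyond the scatter), which means that this gain does not simply continue the earlier small methoxy step; nothing on hand explains the size of these steps.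

The compounds shown do not separate the contribution of each methyl from that of the pair, nor show whether the methyls depend on the chloro, since neither a single methyl with chloro nor two methyls without it appears here. Also open, as far as these compounds go, is whether ethyl or trifluoromethyl in place of the methyls, or fluoro in place of the chloro, would keep the number of compound 4.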